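The compounds below may be only part of what the source reports. "The series", "measured", "known", "first", "only" and "open" are said of these compounds alone.

For the measured compounds named here, compound 1 `COc1ccc(Oc2ccc3c(NCCCNCc4cc(F)ccc4OC)ccnc3c2)cc1` is one of only two compounds with a measured number in an ADME assay on HepG2 cells (Homo sapiens) for cytotoxicity, read by luminescence, CellTiter-Glo and ATP content, with a stated time of 72 h; on this read-out higher numbers stand for an effect only at larger amounts of compound and lower numbers for an effect already at smaller amounts. In this assay compound 1 gives 7000 nM, and compound 2 `COc1cccc(CNCCCNc2ccnc3cc(Oc4cccc(N(C)C)c4)ccc23)c1O` gives 7300 nM in this assay; the two numbers lie within the usual scatter of one another, so the data show no difference between them. Compound 3 `COc1ccc(F)cc1CNCCCNc1ccnc2cc(Cc3cc(C)cc(C)c3)ccc12` has not yet been measured. It differs from compound 1 in one place: 3,5-dimethylbenzyl in place of 4-methoxyphenoxy on an aromatic carbon. Going by the values given here, no measured pair in this set carries that change, so there is no step to lean on. Both measured numbers sit near the same level, and nothing in the data points to a large shift. The move from compound 1 to compound 3 in this assay is expected to be small, a modest fall in the number at most. The estimated step is a 1.4-fold lower number from compound 1 to compound 3 (0.15 log units; within the scatter). Compound 3 is expected to give 5000 nM in this assay, with a range from 2000 nM to 12000 nM.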

Compound 3, half-maximal effective concentration: 940 nM
Estimate against measurement, compound 3: 5.3-fold (0.73 log units) above, and the stated range ends above it.
By their numbers in this assay, from the lowest: compound 3; then compounds 1 and 2 (each within the scatter of the next).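

In this assay this place on an aromatic carbon, meta to a fused ring and para to a fused ring, proves able to move the number: 3,5-dimethylbenzyl in place of 4-methoxyphenoxy gives a 7.4-fold lower number from compound 1 to compound 3 (0.87 log units; beyond the scatter) and so reaches a level that compound 1 and compound 2 did not show. The two groups have the same count of heavy atoms and each holds one six-membered aromatic ring of carbon only, yet 4-methoxyphenoxy carries 2 hydrogen-bond acceptors and 3,5-dimethylbenzyl carries 0. Nothing available explains the step. This single step cannot separate the oxygen link of 4-methoxyphenoxy from the carbon link of 3,5-dimethylbenzyl, nor the methoxy group from the two methyl groups. Going by these compounds, how a plain benzyl, a chlorophenyl or an amine at this place would read in this assay remains open.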